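Thromboxane receptor antagonists: amide in place of acetamidomethyl

The source may hold more compounds than are shown below. What is called first, only, known or untested is meant among the compounds shown, and "the series" means these compounds.

Measured compounds:
- compound 1, `O=C(O)CC/C=C\CO[C@H]1[C@H](OCc2ccc(-c3ccccc3CO)cc2)CC[C@@H]1N1CCCCCC1`: 6.31 nM
- compound 2, `O=C(O)CC/C=C\CO[C@H]1C(OCc2ccc(-c3ccccc3)cc2)CC[C@@H]1N1CCCCCC1`: 12.6 nM
- compound 3, `CC(=O)NCc1ccc(-c2ccc(COC3CC[C@H](N4CCCCCC4)[C@H]3OC/C=C\CCC(=O)O)cc2)cc1`: 2.51 nM

In a functional assay on blood for antagonist activity at thromboxane A2 receptor (Homo sapiens) (on this read-out lower numbers stand for tighter binding and higher numbers for weaker binding), compound 3 gives 2.51 nM, the lowest of the three numbers; compound 1 stands nearest and compound 2 furthest, both beyond the scatter. Compound 4, `NC(=O)c1ccccc1-c1ccc(COC2CC[C@H](N3CCCCCC3)[C@H]2OC/C=C\CCC(=O)O)cc1`, is not yet measured. It differs from compound 3 in one place: 2-carbamoylphenyl in place of 4-(acetamidomethyl)phenyl on an aromatic carbon.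

For the measured compounds named here, one measured step bears on this change. Adding an acetamidomethyl substituent on an aromatic carbon gave a 5.0-fold lower number from compound 2 to compound 3 (0.70 log units; beyond the scatter), so a substituent on that ring has so far been helpful. Going by the values given here, compound 4 carries a carbamoyl where compound 1 carries a hydroxymethyl; compound 1 shows 6.31 nM, and the unsubstituted compound 2 shows 12.6 nM; no single-place step links these two, so only the two values are noted. The carbamoyl of compound 4 keeps one donor and one acceptor but loses the chain that held them away from the ring, so compound 4 is expected to land between compound 1 and compound 3, with a step of a 1.8-fold higher number from compound 3 to compound 4 (0.25 log units; within the scatter) in this assay. The estimate for compound 4 is 4.5 nM, within 1.5 nM to 13 nM.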

Compound 4, dissociation constant: 15.9 nM
For compound 4 the middle estimate is 3.5-fold (0.55 log units) below the measured one, and the stated range ends below it.
By their numbers in this assay, from the lowest: compound 3; then compounds 1, 2 and 4 (each within the scatter of the next, the first and the last beyond it).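

In this assay, 2-carbamoylphenyl in place of 4-(acetamidomethyl)phenyl gives a 6.3-fold higher number from compound 3 to compound 4 (0.80 log units; beyond the scatter) and so gives up the advantage of compound 3. Carbamoyl in place of hydrogen gives a 1.3-fold higher number from compound 2 to compound 4 (0.10 log units; within the scatter), so the earlier result of a 5.0-fold lower number from compound 2 to compound 3 (0.70 log units; beyond the scatter) does not extend to every substituent on that ring and, among the compounds compared here, belongs to the 4-(acetamidomethyl)phenyl group. The two groups have the same computed hydrogen-bond donor and acceptor counts, so those counts do not track this step. No supporting measurement accompanies these steps, and no cause can be assigned. The compounds shown do not separate the place of the substituent on the ring from its identity. From the compounds shown here alone, how an aminomethyl group or a carboxylic acid in place of the acetamidomethyl would read in this assay remains open.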